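The source may hold more compounds than are shown below. What is called first, only, known or untested is meant among the compounds shown, and "the series" means these compounds.

Measured so far:
compound 1, `CN1CCN(C(=S)SCCCOc2ccc(C(=O)/C=C/c3ccc(Cl)cc3)cc2)CC1`, 34200 nM
compound 2, `COc1cc(/C=C/C(=O)c2ccc(OCCSC(=S)N3CCCCC3)cc2)cc(OC)c1OC`, 38900 nM
compound 3, `O=C(/C=C/c1ccc(Cl)cc1)c1ccc(OCCSC(=S)N2CCCCC2)cc1`, 26100 nM

In a functional assay on ECa-109 cells for inhibition, with ECa-109 cell line (Homo sapiens) as the target, read by MTT assay, with a stated time of 72 h (a higher number here means a weaker inhibitor, a lower number a stronger inhibitor), compound 3 gives 26100 nM. Compound 1 gives 34200 nM. Compound 2 gives 38900 nM. Compound 3 carries the lowest of the three numbers, but its gaps to compound 1 and to compound 2 both lie within the scatter, so the three compounds cannot be told apart on these numbers, and none of them may be called the strongest inhibitor. For the measured compounds named here, no pair of measured compounds differs in only one place, so no measured single step is available to calibrate the change that follows.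

Compound 4, `O=C(/C=C/c1ccc(Cl)cc1)c1ccc(OCCCSC(=S)N2CCCC2)cc1`, has not yet been measured in this assay. It differs from compound 3 in this way: a group of 9 heavy atoms (6 carbon, 1 nitrogen, 2 sulfur; one five-membered non-aromatic ring with 1 hetero atom) in place of a group of 9 heavy atoms (6 carbon, 1 nitrogen, 2 sulfur; one six-membered non-aromatic ring with 1 hetero atom), on a saturated chain carbon, two bonds along the chain from an oxygen on an aromatic ring. The two compounds have the same atoms, joined differently. Given that compound 3 gives 26100 nM and that the change swaps one ring size for another at the same place, the step from compound 3 to compound 4 is expected to be none beyond the scatter, a 1.0-fold higher number from compound 3 to compound 4 (0.01 log units; within the scatter). Compound 4 is therefore estimated at 27000 nM, with a range from 10000 nM to 70000 nM.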

Compound 4, half-maximal inhibitory concentration: 18600 nM
Estimate against measurement, compound 4: 1.5-fold (0.16 log units) above, and the stated range covers the measured number.
By their numbers in this assay, from the lowest: compounds 4, 3, 1 and 2 (each within the scatter of the next, the first and the last beyond it).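

For the compounds shown here, the exchange of the six-membered ring for the five-membered ring, on a saturated chain carbon, two bonds along the chain from an oxygen on an aromatic ring, gives the first measured step here in this assay (a 1.4-fold lower number from compound 3 to compound 4 (0.15 log units; within the scatter)). Pyrrolidin-1-yl in place of 4-methylpiperazin-1-yl on a thiocarbonyl carbon gives the second (a 1.8-fold lower number from compound 1 to compound 4 (0.26 log units; within the scatter)), and since both steps lie within the scatter, neither exchange has a readable effect on the number in this assay. Nothing measured here speaks to the basis of this result.

On these data alone, whether any group at this place can move the number beyond the scatter remains open. Morpholin-4-yl or diethylamino on the thiocarbonyl carbon would test this directly against compound 4.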